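Lengthening the chain of compound 2

The compounds below may be only part of what the source reports. "The series", "measured", "known", "first", "only" and "open" are said of these compounds alone.

Compound 1 `Clc1ccc(CCCN2CCC(COC(c3ccccc3)c3ccccc3)CC2)cc1` gives 500 nM
Compound 2 `CCCCCCCN1CCC(COC(c2ccccc2)c2ccccc2)CC1` gives 500 nM

In a functional assay on cells (T-cell line, Homo sapiens) for inhibition (a higher number here means a weaker inhibitor, a lower number a stronger inhibitor), compound 2 gives 500 nM and stands level with compound 1 at the digits reported. Compound 3 `CCCCCCCCN1CCC(COC(c2ccccc2)c2ccccc2)CC1` has methyl in place of hydrogen on a saturated chain carbon, seven bonds along the chain from an amine nitrogen in a ring. Within the data shown here, the one measured step on this chain (no change at the digits printed from compound 1 to compound 2 (within the scatter)) swapped a different group and stayed within the scatter. No step beyond the scatter is therefore expected: the estimated outcome is no change at the digits printed from compound 2 to compound 3 (within the scatter) in this assay and nothing larger. Compound 3 is expected at 500 nM (estimated range 200 nM to 1200 nM).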

Compound 3, half-maximal inhibitory concentration: 700 nM
For compound 3 the middle estimate is 1.4-fold (0.15 log units) below the measured one, and the stated range covers the measured number.
By their numbers in this assay, from the lowest: compounds 1, 2 and 3 (each within the scatter of the next).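

In this assay, methyl in place of hydrogen on a saturated chain carbon, seven bonds along the chain from an amine nitrogen in a ring, gives a 1.4-fold higher number from compound 2 to compound 3 (0.15 log units; within the scatter) and so leaves the read-out within the scatter at this position. Pentyl in place of 4-chlorophenyl gives a 1.4-fold higher number from compound 1 to compound 3 (0.15 log units; within the scatter) and also stays within the scatter, so these two chain ends read alike here. No measured evidence bears on this result.

Still open, as far as these compounds go, is whether a longer chain, or an amine or a carboxylic acid at the chain end, would give a step beyond the scatter.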